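This account rests on a few compounds, and the source may have more. Where it says the series, first, only, none or still open, it means among the compounds named here.

In a functional assay on MCF7 cells (Homo sapiens) for antiproliferative activity, read by MTT assay, with a stated time of 72 h (on this read-out higher numbers stand for weaker inhibition and lower numbers for stronger inhibition), compound 1 `O=C(N/N=C/c1ccccc1)Nc1ccc(Oc2ccnc3[nH]ccc23)c(F)c1` gives 2380 nM and compound 2 `O=C(N/N=C/c1ccc(F)cc1Cl)Nc1ccc(Oc2ccnc3[nH]ccc23)c(F)c1` gives 7610 nM. Going by the values given here, compound 3 `O=C(N/N=C/c1ccc(O)cc1)Nc1ccc(Oc2ccnc3[nH]ccc23)c(F)c1` is recorded as "not active" (no number reported), with no number reported, so it has no measured step to any neighbour. Compound 4 `O=C(N/N=C/c1cc(Br)c(O)c(Br)c1)Nc1ccc(Oc2ccnc3[nH]ccc23)c(F)c1` differs from compound 3 by 3,5-dibromo-4-hydroxyphenyl in place of 4-hydroxyphenyl on a carbon with a double bond to nitrogen, with 3,5-dibromo-4-hydroxyphenyl in place of 4-hydroxyphenyl. Among the compounds with values here, the only measured step at this place is a 3.2-fold higher number from compound 1 to compound 2 (0.50 log units; beyond the scatter), which is modest and goes toward weaker inhibition. Within the data shown here, it gives a rough scale only, and no size of step from compound 3 can be stated. A weak reading is expected for compound 4, or possibly no number at all. In this assay the estimated value for compound 4 is 6000 nM, within an expected range from 1500 nM to 25000 nM.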

Compound 4, half-maximal inhibitory concentration: "not active" (no number reported)
Compound 4: no number reported; there is nothing to compare the estimate with.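

In this assay compound 3 and compound 4 are both recorded as not active without a number, so no step can be read between them. On these data alone, how far either lies from compound 1 remains open. No measured evidence bears on this result.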